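The source may report more compounds than this note shows. Statements on the series, on what has been measured and on what is new or still open speak of the compounds shown alone.

Compound 1 `O=C(c1ccc(-c2nc(-c3ccccn3)no2)s1)C(F)(F)F`, compound 2 `O=C(c1ccc(-c2nc(-c3cccnc3)no2)s1)C(F)(F)F` and compound 3 `O=C(c1ccc(-c2nc(-c3ccc(F)cc3F)no2)s1)C(F)(F)F` share one core and differ only in the aromatic group on it. In an assay for inhibition of histone deacetylase 4 (Homo sapiens) (on this read-out lower numbers stand for stronger inhibition and higher numbers for weaker inhibition), compound 1 gives 90 nM, compound 2 gives 70 nM and compound 3 gives 120 nM. On the numbers shown compound 3 sits at the high end, yet the steps of a 1.3-fold higher number from compound 1 to compound 3 (0.12 log units; within the scatter) and a 1.7-fold higher number from compound 2 to compound 3 (0.23 log units; within the scatter) both lie within the scatter, as does a 1.3-fold lower number from compound 1 to compound 2 (0.11 log units; within the scatter). Compound 4 `Cc1cccc(-c2noc(-c3ccc(C(=O)C(F)(F)F)s3)n2)c1` carries the change (3-methylphenyl in place of 2,4-difluorophenyl on an aromatic carbon), and every measured step swaps the group at this same position, none moving beyond the scatter. A step of a 1.2-fold lower number from compound 3 to compound 4 (0.08 log units; within the scatter) is therefore expected, that is, no real change. Compound 4 is estimated at 100 nM in this assay, within 45 nM to 220 nM.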

Compound 4, half-maximal inhibitory concentration: 280 nM
Estimate against measurement, compound 4: 2.8-fold (0.45 log units) below, outside the stated range (above it).
By their numbers in this assay, from the lowest: compounds 2, 1 and 3 (each within the scatter of the next); then compound 4.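

Within the data shown here, this position proved less indifferent than the earlier compounds suggested: 3-methylphenyl is the first group here to move the number beyond the scatter, with a 2.3-fold higher number from compound 3 to compound 4 (0.37 log units; beyond the scatter) and a 4.0-fold higher number from compound 2 to compound 4 (0.60 log units; beyond the scatter) and also a 3.1-fold higher number from compound 1 to compound 4 (0.49 log units; beyond the scatter) as modest steps. Pyridin-2-yl, pyridin-3-yl and 2,4-difluorophenyl remain within the scatter of one another, so compound 4 alone stands apart, on the weaker side. Nothing available explains this shift. As far as these compounds go, it remains open whether the methyl group itself drives the step, and whether an amine or a carboxylic acid on the phenyl ring would be tolerated at this position.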